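Series notes, step from compound 3 to compound 4

The source may report more compounds than this note shows. Statements on the series, on what has been measured and on what is new or still open speak of the compounds shown alone.

Of the compounds shown here, three have been measured in a functional assay on SF-539 cells (Homo sapiens) for cytotoxicity, read by sulforhodamine B assay, with a stated time of 48 h; on this read-out higher numbers stand for lower toxicity in this test and lower numbers for higher toxicity in this test. Compound 1 `ClCc1ccc(Cn2cnc3c(Cl)ncnc32)cc1` gives 70800 nM, compound 2 `Nc1nc(Cl)c2ncn(Cc3ccc(CCl)cc3)c2n1` gives 46800 nM, and compound 3 `ClCc1ccc(Cn2cnc3ncnc(Cl)c32)cc1` gives 6760 nM. Compound 3 holds the lowest number of the three, that is the highest toxicity in this test, with compound 2 nearest and compound 1 furthest, both gaps beyond the scatter. Among the measured compounds shown here, the only measured step, a 1.5-fold lower number from compound 1 to compound 2 (0.18 log units; within the scatter), concerns a different substitution and stayed within the scatter. Compound 4 `ClCc1ccc(Cn2cnc3nc(Cl)nc(Cl)c32)cc1` differs from compound 3 by chloro in place of hydrogen on an aromatic carbon. For the measured compounds named here, no measured step bears on this change, so the expected step of a 1.2-fold lower number from compound 3 to compound 4 (0.09 log units; within the scatter) is placed at nothing beyond the scatter, with a wide range. Compound 4 is therefore estimated at 5500 nM, between 1500 nM and 20000 nM in this assay.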

Compound 4, concentration lethal to 50% of the cells: 5880 nM
Estimate against measurement, compound 4: 1.1-fold (0.03 log units) below; the measured number falls inside the stated range.
By their numbers in this assay, from the lowest: compounds 4 and 3 (each within the scatter of the next); then compounds 2 and 1 (each within the scatter of the next).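

Adding a chloro group at the place between two ring nitrogen atoms gives a 1.1-fold lower number from compound 3 to compound 4 (0.06 log units; within the scatter) in this assay and stays within the scatter. On the core of compound 3, this position therefore accepts a chloro group without a change that can be read in this test. Nothing measured offers an account of this result.

Open, as far as these compounds go, is whether an amine, a methoxy group or a longer chain at this place would also leave the number within the scatter of compound 3.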